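A Fluoro Group Added to a Weak Alpha-1 Binder

The source may hold more compounds than are shown below. What is called first, only, known or untested is meant among the compounds shown, and "the series" means these compounds.

Compound 1 `COc1ccccc1N1CCN(CCCn2ncc(=O)n(C)c2=O)CC1`: > 10000 nM
Compound 2 `Cn1c(=O)cnn(CCCN2CCN(c3ccccc3)CC2)c1=O`: > 10000 nM

In an assay for displacement of a labelled ligand from Adrenergic receptor alpha-1 (Homo sapiens) (on this read-out higher numbers stand for weaker inhibition and lower numbers for stronger inhibition), compound 1 gives > 10000 nM, which is a limit of the assay rather than a number. Compound 2 gives > 10000 nM in this assay, again only a limit. The two differ by a hydrogen in place of a methoxy on an aromatic carbon, yet the step that the two limits leave unreadable from compound 1 to compound 2 cannot be read, because the limit of > 10000 nM in this assay, at which 2 of the 2 values shown sit, and the change between them therefore leaves no trace in the numbers. Where compound 2 stands is thus known only as a limit: at or beyond the top of the measurable range.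

Compound 3 `Cn1c(=O)cnn(CCCN2CCN(c3ccccc3F)CC2)c1=O` differs from compound 2 by fluoro in place of hydrogen on an aromatic carbon. For the measured compounds named here, no measured step bears on this change; the single measured step is unreadable. No shift beyond the usual scatter is therefore expected in this assay, and the step is estimated as a step that the limit leaves unreadable from compound 2 to compound 3. Compound 3 is expected to give about 15000 nM, within 3000 nM to 60000 nM, most likely reported once more as a limit.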

Compound 3, inhibition constant: > 10000 nM
Compound 3: a limit, no number; the forecaster's own chance of this, stated with the estimate: 75%; the middle value lies beyond the limit too.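

In this assay, for the compounds shown here, compound 3 also gives only a limit, so no step among compound 1, compound 2 and compound 3 can be read, because all three stop at the same point: the limit of > 10000 nM in this assay, at which 3 of the 3 values shown sit.

The compounds shown leave open how strongly any of the three binds, and whether methoxy, hydrogen or fluoro on that aromatic carbon makes any difference.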